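Phenoxy to hydroxy on the anilino ring of the thiourea series

This account rests on a few compounds, and the source may have more. Where it says the series, first, only, none or still open, it means among the compounds named here.

Two compounds of the series have been run in a functional assay on MDA-MB-231 cells (Homo sapiens) for inhibition, read by MTT assay, with a stated time of 48 h; a higher number here means a weaker inhibitor of growth, a lower number a stronger inhibitor of growth. Compound 1 `CC(C)(C)c1ccc(Nc2ncnc3ccc(NC(=S)NCc4ccccc4)cc23)cc1` gives 8700 nM, and compound 2 `S=C(NCc1ccccc1)Nc1ccc2ncnc(Nc3ccc(Oc4ccccc4)cc3)c2c1` gives 6800 nM. Compound 2 has the lower of the two numbers, but the step of a 1.3-fold lower number from compound 1 to compound 2 (0.11 log units; within the scatter) is within the scatter, so the two sit together. Compound 3 `Oc1ccc(Nc2ncnc3ccc(NC(=S)NCc4ccccc4)cc23)cc1` is not yet measured; relative to compound 2 the change is hydrogen in place of phenyl on an oxygen on an aromatic ring. Among the compounds with values here, no measured step touches the oxygen of the phenoxy group; the only step on record, a 1.3-fold lower number from compound 1 to compound 2 (0.11 log units; within the scatter), exchanges whole substituents at the same aromatic carbon and moved the number by little. On that thin basis no step beyond the scatter is expected in this assay, with the uncertainty left wide. Compound 3 is estimated at 9000 nM, with a range of 3500 nM to 25000 nM, which amounts to an expected step of a 1.3-fold higher number from compound 2 to compound 3 (0.12 log units; within the scatter).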

Compound 3, concentration for 50% growth inhibition: 27000 nM
Beside the measured number, compound 3's estimate is 3.0-fold (0.48 log units) below it, and the stated range ends below it.
By their numbers in this assay, from the lowest: compounds 2 and 1 (each within the scatter of the next); then compound 3.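

Within the data shown here, at this aromatic carbon, the exchange of tert-butyl for phenoxy stayed within the scatter, but hydroxy is the first group to move the number beyond it in this assay. Cutting the phenyl from the oxygen gives a 4.0-fold higher number from compound 2 to compound 3 (0.60 log units; beyond the scatter) and replacing tert-butyl with hydroxy gives a 3.1-fold higher number from compound 1 to compound 3 (0.49 log units; beyond the scatter) in the same direction, which leaves compound 3 the weakest of the three. Compound 3 keeps the oxygen on the aromatic ring, so that oxygen alone does not preserve the number of compound 2.

No available evidence accounts for this step. Going by these compounds, it remains open whether a methoxy group or a longer alkoxy chain on the oxygen would sit with compound 2 or compound 3, and whether an amine at the same aromatic carbon would follow hydroxy.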